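The compounds below may be only part of what the source reports. "The series", "measured", "known", "first", "only" and "open" are said of these compounds alone.

Going by the values given here, in a functional assay (mast cells) for inhibition, with Rattus norvegicus as the target (on this read-out higher numbers stand for an effect only at larger amounts of compound and lower numbers for an effect already at smaller amounts), compound 2 `CC(=O)c1ccc(N/N=C2\CCC(C)n3c2ncc(C(=O)O)c3=O)cc1` gives 8100 nM as the highest of two numbers so far, while compound 1 `CC1CC/C(=N\Nc2ccc(Br)cc2)c2ncc(C(=O)O)c(=O)n21` gives 2000 nM as its nearest neighbour. Compound 3 `CNC(=O)c1ccc(N/N=C2\CCC(C)n3c2ncc(C(=O)O)c3=O)cc1` differs from compound 2 by methylamino in place of methyl on a carbonyl carbon. Among the compounds with values here, one measured step bears on this: acetyl in place of bromo on an aromatic carbon, which gave a 4.1-fold higher number from compound 1 to compound 2 (0.61 log units; beyond the scatter) as a modest change beyond the scatter. That single step gives no direction for the new change, so no step beyond the scatter is expected in this assay here. The expected step is a 1.0-fold lower number from compound 2 to compound 3 (0.01 log units; within the scatter) on this estimate. Compound 3 is estimated at 8000 nM within a range of 2500 nM to 25000 nM for now.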

Compound 3, half-maximal effective concentration: 100000 nM
Compound 3: the middle estimate sits 13-fold (1.10 log units) below what was measured; measured number above the stated range.
By their numbers in this assay, from the lowest: compound 1; then compound 2; then compound 3.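

In this assay, the end group on this carbonyl carbon matters: methylamino in place of methyl gives a 12-fold higher number from compound 2 to compound 3 (1.09 log units; beyond the scatter), so the acetyl and methylcarbamoyl compounds are not interchangeable. Methylcarbamoyl in place of bromo on the aromatic carbon gives a 50-fold higher number from compound 1 to compound 3 (1.70 log units; beyond the scatter), a wider separation within the series than the acetyl compound showed. No available measurement accounts for this loss. Open, going by these compounds, is whether the step follows from the hydrogen-bond donor of methylamino or from the added nitrogen alone. Dimethylamino or ethyl on the same carbonyl carbon would separate these two readings.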